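Halobenzyl ethers of the shared core: bromo for cyano

A few compounds are considered here, and "the series" means these few. Any claim that something is new, unique, unknown or untested is made for them only; others in the source may bear on it.

Among the measured compounds shown here, in a functional assay on the whole organism with Mus musculus as the target, with a stated time of 1 h, at a dose of 100 mg/kg by the intraperitoneal route (a lower number here means less inhibition, a higher number more inhibition at the dose given (going by the name of the read-out)), compound 1 `Fc1ccc(COc2nc3ccccc3s2)cc1` gives 90.7%, while compound 2 `N#Cc1ccc(COc2nc3ccccc3s2)cc1` gives 12.7%, the lowest of the two numbers so far; its nearest neighbour is compound 1, and the single measured step, a number 78 percentage points lower from compound 1 to compound 2 (beyond the scatter), runs beyond the scatter. Compound 3 `Brc1ccc(COc2nc3ccccc3s2)cc1` is not yet measured. Its difference from compound 2 is bromo in place of cyano on an aromatic carbon, on the aromatic carbon of a six-membered aromatic ring of carbon only, para to a large group. For the measured compounds named here, the only step that bears on this change is the one from compound 1 to compound 2, where cyano replaced fluoro and the number fell hard; going back from cyano to another halogen, bromo, is therefore expected to move the number upward by a large amount, though with wide uncertainty since no bromo analogue exists in the set. Compound 3 is expected at 70%, with a range of 30% to 95%, meaning an expected step of a number 57.3 percentage points higher from compound 2 to compound 3 (beyond the scatter).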

Compound 3, a percentage reported as inhibition, in the whole organism at one dose (the size of the read-out at that dose, not a potency): 78%
Estimate against measurement, compound 3: 8 percentage points below, within the range that was stated.
By their numbers in this assay, from the lowest: compound 2; then compound 3; then compound 1.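

In this assay, bromo in place of cyano on an aromatic carbon gives a number 65.3 percentage points higher from compound 2 to compound 3 (beyond the scatter) and so shows that the low number of compound 2 does not extend to every replacement of fluoro at this place, para to a large group. The two halogens still differ, since bromo in place of fluoro gives a number 12.7 percentage points lower from compound 1 to compound 3 (beyond the scatter) and this modest step leaves compound 1 the highest of the three. Nothing available explains either step.

The compounds shown carry only fluoro, bromo and cyano at this place, all on the shared core and read at one dose and one time. From the compounds shown here alone, whether an amine, a carboxylic acid or a methoxy group here would stand nearer the two halogens or the nitrile remains open, as does the position of chloro relative to fluoro and bromo.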